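The compounds below may be only part of what the source reports. "The series", "measured", "known", "first", "only" and "open" are said of these compounds alone.

Compound 1 `Cc1ccc(NC(=O)c2cccc(C(F)(F)F)c2)cc1OC1CCN(C(=O)c2cccnc2)CC1`: in an ADME assay on BaF3 cells (Mus musculus) for antiproliferative activity (a higher number here means a weaker inhibitor of growth, a lower number a stronger inhibitor of growth), compound 1 gives > 10000 nM, a limit of the assay rather than a number.
Compound 2 `Cc1ccc(NC(=O)c2cccc(C(F)(F)F)c2)cc1OC1CCN(C(=O)c2ccccn2)CC1`: in this assay compound 2 gives > 10000 nM, again only a limit.
Compound 3 `COc1ccc(NC(=O)c2cccc(C(F)(F)F)c2)cc1OC1CCN(C(=O)c2cccnc2)CC1`: in this assay compound 3 gives > 10000 nM, again only a limit.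

Compound 1 therefore stands at the limit of > 10000 nM in this assay, at which 3 of the 3 values shown sit, with no measured number of its own. Compound 4 `COc1cccc(C(=O)Nc2ccc(C)c(OC3CCN(C(=O)c4cccnc4)CC3)c2)c1` differs from compound 1 by methoxy in place of trifluoromethyl on an aromatic carbon. The two measured steps from compound 1 are a step that the two limits leave unreadable from compound 1 to compound 2 and a step that the two limits leave unreadable from compound 1 to compound 3; both begin and end at the limit, so neither shows how far any change moves growth inhibition in this series, and neither touches the trifluoromethyl group. The step expected is a step that the limit leaves unreadable from compound 1 to compound 4. Compound 4 is estimated to give 15000 nM, within 5000 nM to 50000 nM, most likely again as a limit.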

Compound 4, concentration for 50% growth inhibition: > 10000 nM
Compound 4: a limit, no number; the forecaster's own chance of this, stated with the estimate: 85%; the middle value is on the limit's open side.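

Compound 1 and compound 4 both give only a limit, not a number, so the step between them cannot be read: the limit of > 10000 nM in this assay, at which 4 of the 4 values shown sit.

The compounds shown leave open which change to the shared core, if any, would bring a measurable number in this assay.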